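The compounds below may be only part of what the source reports. "The series", "measured", "known", "first", "only" and "open" are said of these compounds alone.

Working notes on the series. Of the compounds shown here, three carrying the shared core have been measured in an assay for inhibition of CDK8/Cyclin C (Homo sapiens), read by fluorescence polarization; a lower number here means a stronger inhibitor, a higher number a weaker inhibitor. Compound 1 `Clc1ccc(Oc2cncc3sc(-c4nn[nH]n4)cc23)cc1` gives 1.1 nM in this assay. Compound 2 `Cc1ccc(Oc2cncc3sc(-c4nn[nH]n4)cc23)cc1` gives 1.6 nM, and compound 3 `CC(=O)Nc1ccc(Oc2cncc3sc(-c4nnn[nH]4)cc23)cc1` gives 2 nM. Compound 1 shows the lowest of the three numbers, yet both others sit within the scatter of it, so no order among the three can be read from these values. For the measured compounds named here, the one single-point step recorded so far, a 1.5-fold higher number from compound 1 to compound 2 (0.16 log units; within the scatter), concerns the substituent on the pendant aryl ring and stays within the scatter.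

Compound 4 `O=C(O)c1cc2c(Oc3ccc(Cl)cc3)cncc2s1` differs from compound 1 at the other end of the molecule: carboxy in place of 2H-tetrazol-5-yl on an aromatic carbon. Going by the values given here, none of the measured steps touches this group, so no recorded step bears directly on the change; all three measured compounds carry the tetrazole, and every variation so far has left the number within the scatter. Among the compounds with values here, with no precedent for this exchange, a step beyond the scatter toward a higher number is considered possible but not established, and the estimate is placed close to compound 1 with a wide range. The expected step is a 3.6-fold higher number from compound 1 to compound 4 (0.56 log units; beyond the scatter). Compound 4 is therefore estimated at 4 nM in this assay, with a range from 1 nM to 25 nM.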

Compound 4, half-maximal inhibitory concentration: 2.8 nM
Compound 4: the middle estimate sits 1.4-fold (0.15 log units) above what was measured; measured number inside the range.
By their numbers in this assay, from the lowest: compounds 1, 2, 3 and 4 (each within the scatter of the next, the first and the last beyond it).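

Compound 4 gives the first step in the series at the aromatic carbon next to the ring sulfur: in this assay, carboxy in place of 2H-tetrazol-5-yl gives a 2.5-fold higher number from compound 1 to compound 4 (0.41 log units; beyond the scatter) and is the only listed step beyond the scatter, so this position does register the exchange. The step is modest, and the tetrazole ring can be given up here with compound 4 still at 2.8 nM in this assay. No measurement at hand offers an explanation for this step.

As far as these compounds go, how a primary amide, a methyl ester or a nitrile would read at this position remains open. Also open, from the compounds shown here alone, is whether the step from tetrazole to carboxy holds with methyl in place of chloro on the pendant aryl ring.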